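A Carboxy Group Becomes a Propyl Amide

This account rests on a few compounds, and the source may have more. Where it says the series, first, only, none or still open, it means among the compounds named here.

Measured in a functional assay on cells (Platelet, Homo sapiens) for inhibition; a higher number here means a weaker inhibitor, a lower number a stronger inhibitor:
Compound 1 `CCCCn1nc(-c2ccc(C(=O)OCC)cc2)c2ccccc21`: 670 nM
Compound 2 `O=C(O)c1ccc(-c2nn(Cc3ccccc3)c3ccccc23)cc1`: > 10000 nM

Compound 2 gives > 10000 nM, which is a limit of the assay and not a number. It therefore marks a floor for the reading rather than an exact position, and any change from compound 2 can only be judged against that limit.

Compound 3 `CCCNC(=O)c1ccc(-c2nn(Cc3ccccc3)c3ccccc23)cc1` keeps the core of compound 2 but has propylamino in place of hydroxy on a carbonyl carbon, so carboxy becomes propylcarbamoyl (propylamino in place of hydroxy on a carbonyl carbon).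

Going by the values given here, no measured pair shows this change on its own, so the expectation rests on thin evidence. Compound 1, whose carbonyl carbon also carries no hydroxy, gives 670 nM in this assay, and this points towards a measurable reading for compound 3. The expected step in this assay is towards stronger inhibition and beyond the usual scatter, estimated as an at least 4.0-fold lower number from compound 2 to compound 3 (0.60 log units; beyond the scatter). Compound 3 is expected at about 2500 nM, with an estimated range of 500 nM to 10000 nM.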

Compound 3, half-maximal inhibitory concentration: > 10000 nM
Compound 3: no number, only a limit; the forecaster's own chance of this, stated with the estimate: 25%; at least 4.0-fold (0.60 log units) between middle value and limit.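

No step can be read from compound 2 to compound 3 in this assay, since the readings of both compounds are limits of the assay and not numbers: the limit of > 10000 nM in this assay, at which 2 of the 3 values shown sit.

The compounds shown leave open how strongly compound 2 and compound 3 actually inhibit, and whether swapping carboxy for propylcarbamoyl changes the inhibition at all.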